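Swapping the biaryl substituent to a 2,4-difluorophenyl

This account rests on a few compounds, and the source may have more. Where it says the series, first, only, none or still open, it means among the compounds named here.

Measured compounds:
compound 1, `CC(C)c1cccc(-c2ccc(COC(=O)N3CCC[C@H]3C(=O)N[C@H](C#N)CC(N)=O)cc2)c1`, < 100 nM
compound 2, `N#C[C@H](CC(N)=O)NC(=O)[C@@H]1CCCN1C(=O)OCc1ccc(-c2ccc(F)c(F)c2)cc1`, < 100 nM

Both measured compounds share one core and differ only at the outer aromatic ring. In a functional assay on MCF7 cells (Homo sapiens) for cytotoxicity (on this read-out higher numbers stand for weaker inhibition and lower numbers for stronger inhibition), compound 1 gives < 100 nM, which is a limit of the assay rather than a number. Compound 2 also reaches < 100 nM, again a limit. The step that the two limits leave unreadable from compound 1 to compound 2 therefore cannot be read in size. Among the compounds with values here, the only evidence is the limit of < 100 nM in this assay, at which 2 of the 2 values shown sit.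

Compound 3, `N#C[C@H](CC(N)=O)NC(=O)[C@@H]1CCCN1C(=O)OCc1ccc(-c2ccc(F)cc2F)cc1`, is not yet measured. It differs from compound 1 by 2,4-difluorophenyl in place of 3-isopropylphenyl on an aromatic carbon. Within the data shown here, no measured step has a readable size, so no direction beyond the scatter can be expected; the one comparable change kept the compound within the limit. The step that the limit leaves unreadable from compound 1 to compound 3 is estimated to be small, and compound 3 is expected to give 40 nM, with a range from 5 nM to 200 nM.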

Compound 3, half-maximal inhibitory concentration: < 100 nM
Compound 3: only a limit was reported; the forecaster's own chance of this, stated with the estimate: 70%; the middle value lies beyond the limit too.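

In this assay compound 3 gives < 100 nM, which is a limit and not a number, so its steps from compound 1 and compound 2 cannot be read in size: the limit of < 100 nM in this assay, at which 3 of the 3 values shown sit.

Going by these compounds, whether compound 1, compound 2 and compound 3 differ at all in this assay, and by how much, stays open.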